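This account rests on a few compounds, and the source may have more. Where it says the series, first, only, none or still open, it means among the compounds named here.

Measured so far:
Compound 1 `Oc1cccc(-c2cc(-c3cccc(C(F)(F)F)c3)cc(-c3cccc(O)c3)n2)c1` gives > 50000 nM in a functional assay on DU-145 cells (Homo sapiens) for inhibition (on this read-out lower numbers stand for stronger inhibition and higher numbers for weaker inhibition), a limit of the assay rather than a number.
Compound 2 `Oc1ccc(-c2cc(-c3cccc(C(F)(F)F)c3)cc(-c3cccc(O)c3)n2)cc1` gives 11100 nM in this assay.
Compound 3 `Oc1ccc(-c2cc(-c3ccccc3OC(F)(F)F)cc(-c3cccc(O)c3)n2)cc1` gives 7760 nM in this assay.

All three share a core carrying three aromatic groups. Compound 2 differs from compound 1 by a single change, (4-hydroxyphenyl in place of 3-hydroxyphenyl on an aromatic carbon), and this gave an at least 4.5-fold lower number from compound 1 to compound 2 (0.65 log units; beyond the scatter); the start of that step is a limit (the limit of > 50000 nM in this assay, at which 1 of the 3 values shown sits), so its true size is not known. The values of compound 2 and compound 3 lie within the usual scatter of each other. How the core of compound 3 differs from that of compound 1 is not broken down here.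

Compound 4 `Oc1ccc(-c2cc(-c3ccccc3OC(F)(F)F)cc(-c3ccc(O)cc3)n2)cc1` has not yet been tested. It differs from compound 3 by 4-hydroxyphenyl in place of 3-hydroxyphenyl on an aromatic carbon. This is the same kind of change as from compound 1 to compound 2, but the surroundings differ: here the place is meta to a 4-hydroxyphenyl group and meta to a large group, whereas before it was meta to a 3-(trifluoromethyl)phenyl group and meta to a 3-hydroxyphenyl group. Because an at least 4.5-fold lower number from compound 1 to compound 2 (0.65 log units; beyond the scatter) was at least modest, a step of a 3.1-fold lower number from compound 3 to compound 4 (0.49 log units; beyond the scatter) is expected here, somewhat smaller since the earlier start was only a limit. Compound 4 is thus estimated at 2500 nM, likely between 800 nM and 8000 nM.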

Compound 4, half-maximal inhibitory concentration: 16000 nM
For compound 4 the middle estimate is 6.4-fold (0.81 log units) below the measured one; the measured number lies above the stated range.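

In this assay, 4-hydroxyphenyl in place of 3-hydroxyphenyl gives a 2.1-fold higher number from compound 3 to compound 4 (0.31 log units; beyond the scatter), so the number rises on this core where it fell on the earlier one. The same change therefore does not carry over between these two cores, not even in its direction: the same change on two cores in this assay, an at least 4.5-fold lower number (0.65 log units; beyond the scatter) from compound 1 to compound 2 and a 2.1-fold higher number (0.31 log units; beyond the scatter) from compound 3 to compound 4, at least 9.2-fold (0.96 log units) apart, beyond the scatter of two such steps

Compound 1 sits at a limit of the assay and not at a number, so the size of the earlier step stays unknown, and two cores alone cannot show why the steps part or what a third core would do: the limit of > 50000 nM in this assay, at which 1 of the 4 values shown sits.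

From the compounds shown here alone, it remains open how this change behaves on a core whose third aromatic group carries neither trifluoromethyl nor trifluoromethoxy, for instance a plain phenyl. The compounds shown also leave open whether an amine or a carboxylic acid in place of the hydroxyl on either ring would give lower numbers in this assay.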